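From 4-(dimethylamino)phenyl to methoxy in a HepG2 series

The compounds below may be only part of what the source reports. "The series", "measured", "known", "first", "only" and "open" are said of these compounds alone.

In a functional assay on HepG2 cells (Homo sapiens) for inhibition, read by MTT assay, with a stated time of 72 h (a lower number here means a stronger inhibitor, a higher number a weaker inhibitor), compound 1 `Cc1ccc(-c2cc(C(=O)N3CCC4(CC3)CC(=O)c3nn(C(C)(C)C)cc3O4)c3ccccc3n2)cc1` gives 1440 nM, compound 2 `COc1ccc(-c2cc(C(=O)N3CCC4(CC3)CC(=O)c3nn(C(C)(C)C)cc3O4)c3ccccc3n2)cc1OC` gives 1560 nM and compound 3 `CN(C)c1ccc(-c2cc(C(=O)N3CCC4(CC3)CC(=O)c3nn(C(C)(C)C)cc3O4)c3ccccc3n2)cc1` gives 1730 nM. The three values sit close together, and compound 3 cannot be separated from the other two: the steps are a 1.2-fold higher number from compound 1 to compound 3 (0.08 log units; within the scatter) and a 1.1-fold higher number from compound 2 to compound 3 (0.04 log units; within the scatter), alongside a 1.1-fold higher number from compound 1 to compound 2 (0.03 log units; within the scatter).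

Compound 4 `COc1cc(C(=O)N2CCC3(CC2)CC(=O)c2nn(C(C)(C)C)cc2O3)c2ccccc2n1` has methoxy in place of 4-(dimethylamino)phenyl on an aromatic carbon, next to the ring nitrogen: methoxy in place of 4-(dimethylamino)phenyl on an aromatic carbon. The measured steps bear on this change only indirectly. Each keeps a six-membered aromatic ring of carbon at this place and varies only what that ring carries, and none removes it. They show that such variation moved this assay very little, but they do not show what losing the ring does. A modest move towards a weaker number is therefore expected, with wide uncertainty, and the estimated step is a 1.7-fold higher number from compound 3 to compound 4 (0.24 log units; within the scatter). For compound 4 the expected value is 3000 nM, within an estimated range of 1000 nM to 10000 nM.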

Compound 4, half-maximal inhibitory concentration: > 10000 nM
Compound 4: only a limit was reported; the forecaster's own chance of this, stated with the estimate: 10%; middle value at least 3.3-fold (0.52 log units) away from the limit.
By their numbers in this assay, from the lowest: compounds 1, 2 and 3 (each within the scatter of the next). At a limit, above all of these: compound 4.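

In this assay, this place on the core tolerates changes to what the six-membered aromatic ring of carbon carries, but not, in this one case, the loss of that ring. Replacing each of the three ring-bearing groups with methoxy gives an at least 5.7-fold higher number from compound 3 to compound 4 (0.76 log units; beyond the scatter), an at least 6.4-fold higher number from compound 2 to compound 4 (0.80 log units; beyond the scatter) and an at least 6.9-fold higher number from compound 1 to compound 4 (0.84 log units; beyond the scatter), so all three steps are beyond the scatter, unlike the steps among compounds 1, 2 and 3. The value for compound 4 is a limit, not a number: the limit of > 10000 nM in this assay, at which 1 of the 4 values shown sits.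

The compounds shown do not separate the loss of the aromatic ring from the loss of heavy atoms, since methoxy differs from the leaving groups in both. A cyclohexyl ring or a pyridine ring at this place would bear on that, and a small amine would show whether methoxy itself matters.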